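A few compounds are considered here, and "the series" means these few. Any claim that something is new, unique, unknown or untested is made for them only; others in the source may bear on it.

Measured so far in an ADME assay on Vero cells (Chlorocebus sabaeus) for cytotoxicity, read by CellTiter-Glo, with a stated time of 72 h; on this read-out higher numbers stand for lower toxicity in this test and lower numbers for higher toxicity in this test:

Compound 1, `CCOC(=O)Nc1cc(NC(C)CCCN(CC)CC)c2nc(-c3ccco3)c(-c3ccco3)nc2n1`, gives > 40000 nM, which is a limit of the assay and not a number.
Compound 2, `CCOC(=O)Nc1cc(NC(C)CCCN(CC)CC)c2nc(-c3cccs3)c(-c3cccs3)nc2n1`, gives > 40000 nM, again a limit of the assay.
Compound 3, `CCOC(=O)Nc1cc(NCCN(CC)CC)c2nc(-c3cccs3)c(-c3cccs3)nc2n1`, gives 6300 nM.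

Compound 1 and compound 2 carry the same side chain on the shared core but differ in the two aromatic rings attached to it; the difference between the two cores is not broken down here. Compound 2 and compound 3 differ in a single place: 2-(diethylamino)ethyl in place of 4-(diethylamino)-1-methylbutyl on a nitrogen on an aromatic ring. That change produced an at least 6.3-fold lower number from compound 2 to compound 3 (0.80 log units; beyond the scatter), and the step can only be given as a bound because of the limit of > 40000 nM in this assay, at which 2 of the 3 values shown sit.

Compound 4, `CCOC(=O)Nc1cc(NCCN(CC)CC)c2nc(-c3ccco3)c(-c3ccco3)nc2n1`, has not yet been measured in this assay. It stands to compound 1 exactly as compound 3 stands to compound 2, with the same change in the same place: 2-(diethylamino)ethyl in place of 4-(diethylamino)-1-methylbutyl on a nitrogen on an aromatic ring. Among the compounds shown this change occurs twice, and only one of the two pairs has been measured.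

Since compound 1 also sits at the limit, the expectation for compound 4 rests on an at least 6.3-fold lower number from compound 2 to compound 3 (0.80 log units; beyond the scatter): the shorter side chain is expected to bring the value down into the measurable range in the same way. Compound 4 is therefore estimated at 8000 nM, with a likely range from 3000 nM to 40000 nM, which corresponds to an expected step of an at least 5.0-fold lower number from compound 1 to compound 4 (0.69 log units; beyond the scatter).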

Compound 4, half-maximal cytotoxic concentration: 5500 nM
Compound 4: middle estimate off by 1.5-fold (0.16 log units), on the high side; measured number inside the range.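

In this assay, putting 2-(diethylamino)ethyl in place of 4-(diethylamino)-1-methylbutyl on a nitrogen on an aromatic ring gives an at least 7.2-fold lower number from compound 1 to compound 4 (0.86 log units; beyond the scatter), so the change points the same way on a second core, towards higher toxicity in this test. Set side by side, the two pairs agree in direction, and each step lies beyond the usual scatter: the same change on two cores in this assay, an at least 6.3-fold lower number (0.80 log units; beyond the scatter) from compound 2 to compound 3 and an at least 7.2-fold lower number (0.86 log units; beyond the scatter) from compound 1 to compound 4; the limit leaves it open whether they differ. Going by these compounds alone, what this does not show is the true size of either step, or whether the change is worth the same on both cores, and it rests on only two pairs, whose starting compounds both sit at a limit of the assay rather than at a number: the limit of > 40000 nM in this assay, at which 2 of the 4 values shown sit.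

The change shortens the chain and removes its methyl branch at once, so the compounds shown leave open which of the two goes with the lower number; an unbranched 4-(diethylamino)butyl chain would separate them. Also open, from the compounds shown here alone, is how the number responds to a different amine at the end of the chain, such as a pyrrolidine or a morpholine in place of the diethylamino group.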